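A Methyl Group Tested on Two Related Cores

This account rests on a few compounds, and the source may have more. Where it says the series, first, only, none or still open, it means among the compounds named here.

Four compounds share most of their structure and differ in the ring at one end and in a single methyl group. Compound 1 `O=C1NC(=S)S/C1=C\C1=Cc2cc(Br)ccc2OC1` and compound 3 `CC1Oc2ccc(Br)cc2C=C1/C=C1\SC(=S)NC1=O` carry one version of that ring; compound 2 `O=C1NC(=O)/C(=C/C2=Cc3cc(Br)ccc3OC2)N1` and compound 4 `CC1Oc2ccc(Br)cc2C=C1/C=C1\NC(=O)NC1=O` carry another. The difference between the two cores is not broken down here.

In a functional assay on A549 cells (Homo sapiens) for antiproliferative activity, read by MTT assay, with a stated time of 72 h (on this read-out higher numbers stand for weaker inhibition and lower numbers for stronger inhibition), compound 1 gives 51000 nM and compound 3 gives 47500 nM. The change from compound 1 to compound 3 is methyl in place of hydrogen on a saturated ring carbon and it made a 1.1-fold lower number from compound 1 to compound 3 (0.03 log units; within the scatter). Compound 2 gives 19300 nM in this assay, the lowest of the three measured numbers, set apart from compound 1 and from compound 3 by gaps beyond the scatter.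

Compound 4 has not yet been measured. Going by the values given here, it differs from compound 2 by methyl in place of hydrogen on a saturated ring carbon, the same change as the one from compound 1 to compound 3. Because that change made a 1.1-fold lower number from compound 1 to compound 3 (0.03 log units; within the scatter) on the core of compound 1, the expectation for the core of compound 2 is a step of a 1.1-fold lower number from compound 2 to compound 4 (0.03 log units; within the scatter), again within the scatter. Compound 4 is therefore expected to give about 18000 nM in this assay, with an estimated range from 8000 nM to 40000 nM. This expectation rests on a single measured pair, and a second core need not repeat what the first one showed.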

Compound 4, half-maximal inhibitory concentration: 17500 nM
The estimate for compound 4 lay 1.0-fold (0.01 log units) above the measured number, and the stated range covers the measured number.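

On the core of compound 2, the methyl group in place of hydrogen on the saturated ring carbon gave a 1.1-fold lower number from compound 2 to compound 4 (0.04 log units; within the scatter) in this assay, so a change that barely registered on the first core also barely registered on the second. Set side by side, the two steps agree, which means that within this small series the result for this change carried over from one core to the other: the same change on two cores in this assay, a 1.1-fold lower number (0.03 log units; within the scatter) from compound 1 to compound 3 and a 1.1-fold lower number (0.04 log units; within the scatter) from compound 2 to compound 4, 1.0-fold (0.01 log units) apart, within the scatter of two such steps This does not show that the methyl group has no effect at all, since a step within the scatter cannot separate a small real effect from none, and the agreement rests on only two pairs of compounds in a single cell assay.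

The compounds shown leave open whether something other than methyl on that saturated ring carbon, such as an ethyl group, a longer chain, a hydroxyl group or an amine, would also leave the number where it is. They also leave open whether the methyl step would stay this small on a third core or in a different cell line.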